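Fluoro added beside the trifluoromethyl arene in the dienone series

The compounds below may be only part of what the source reports. "The series", "measured", "known", "first", "only" and "open" are said of these compounds alone.

For the measured compounds named here, compound 1 `CC1=C(/C=C/C(=O)/C=C/c2cccc(C(F)(F)F)c2)C(C)(C)CCC1O` is the one member of the series with a number: in a functional assay on PCa 2b cells (Homo sapiens) for cytotoxicity, read by MTT assay, with a stated time of 72 h (a higher number here means a weaker inhibitor, a lower number a stronger inhibitor), compound 1 gives 2600 nM. Compound 2 `CC1=C(/C=C/C(=O)/C=C/c2cccc(F)c2)C(C)(C)CCC1O` has no number: in this assay compound 2 is recorded as "not determined" (no result reported). Going by the values given here, compound 3 `CC1=C(/C=C/C(=O)/C=C/c2ccc(F)c(C(F)(F)F)c2)C(C)(C)CCC1O` carries one change against compound 1, (fluoro in place of hydrogen on an aromatic carbon); no step between measured compounds is available for it. The change is small and is expected to move this assay by no more than the scatter, in no firm direction, giving an expected step of a 1.0-fold lower number from compound 1 to compound 3 (0.02 log units; within the scatter). Compound 3 is therefore estimated at 2500 nM in this assay, within a range of 1200 nM to 5200 nM.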

Compound 3, half-maximal inhibitory concentration: 10000 nM
The estimate for compound 3 lay 4.0-fold (0.60 log units) below the measured number; measured number above the stated range.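

Adding fluoro ortho to a trifluoromethyl group and para to a large group is not a silent change on this arene: in this assay it gives a 3.8-fold higher number from compound 1 to compound 3 (0.59 log units; beyond the scatter) and so weakens the compound. This one pair shows that the position is sensitive to even a single added fluorine atom. No measurement at hand accounts for the loss.

Still open, as far as these compounds go, is whether chloro, methoxy or an amine at this position would weaken the compound in the same way. Also open, from the compounds shown here alone, is whether the fluoro step would hold with a carboxylic acid in place of the trifluoromethyl group.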